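Opening a hydroxylated ring on sulfur

The source may report more compounds than this note shows. Statements on the series, on what has been measured and on what is new or still open speak of the compounds shown alone.

Of the compounds shown here, three sharing one core have been measured in a functional assay on HT cells (Homo sapiens) for antiproliferative activity, read by fluorescence, with a stated time of 72 h; a higher number here means a weaker inhibitor of growth, a lower number a stronger inhibitor of growth. Compound 1 `CC(C)c1n[nH]c2c(NCc3ccc(-c4ccccn4)cc3)nc(SCC3CNC(=O)O3)nc12` gives 80 nM. Compound 2 `CC(C)c1n[nH]c2c(NCc3ccc(-c4ccccn4)cc3)nc(SC(C)C(C)O)nc12` gives 190 nM, and compound 3 `CC(C)c1n[nH]c2c(NCc3ccc(-c4ccccn4)cc3)nc(SC3CCCCC3O)nc12` gives 636 nM, the highest number of the three; the steps of a 2.4-fold higher number from compound 1 to compound 2 (0.38 log units; beyond the scatter), an 8.0-fold higher number from compound 1 to compound 3 (0.90 log units; beyond the scatter) and a 3.3-fold higher number from compound 2 to compound 3 (0.52 log units; beyond the scatter) all lie beyond the scatter, so compound 3 is the weakest inhibitor of growth among them.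

Compound 4 `CCC(CO)Sc1nc(NCc2ccc(-c3ccccn3)cc2)c2[nH]nc(C(C)C)c2n1` has not been measured. It differs from compound 3 by 1-(hydroxymethyl)propyl in place of 2-hydroxycyclohexyl on a sulfur. The step that speaks most directly to this change is a 3.3-fold higher number from compound 2 to compound 3 (0.52 log units; beyond the scatter), where an open-chain hydroxyalkyl group was replaced by the ring-bearing one and the number rose. Compound 4 reverses that kind of change, returning to an open-chain group of the same size as in compound 2, so the number is expected to fall by roughly the same amount, a 2.9-fold lower number from compound 3 to compound 4 (0.46 log units; beyond the scatter). Compound 4 is therefore estimated at 220 nM, within a range of 90 nM to 550 nM.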

Compound 4, concentration for 50% growth inhibition: 255 nM
The estimate for compound 4 lay 1.2-fold (0.06 log units) below the measured number; the range from low to high includes it.
By their numbers in this assay, from the lowest: compound 1; then compounds 2 and 4 (each within the scatter of the next); then compound 3.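

In this assay, a second open-chain group on the sulfur also gives a lower number than the 2-hydroxycyclohexyl group, with a 2.5-fold lower number from compound 3 to compound 4 (0.40 log units; beyond the scatter), so the gap seen with compound 2 is not confined to one chain. The exact open-chain arrangement matters little in this pair: exchanging 2-hydroxy-1-methylpropyl for 1-(hydroxymethyl)propyl gives a 1.3-fold higher number from compound 2 to compound 4 (0.13 log units; within the scatter), yet the (2-oxo-1,3-oxazolidin-5-yl)methyl group keeps its advantage, with a 3.2-fold higher number from compound 1 to compound 4 (0.50 log units; beyond the scatter). Nothing measured here gives a reason for these differences.

As far as these compounds go, it remains open how a longer chain on the sulfur would compare with these two open chains. An amine or a carboxylic acid in place of the hydroxyl is also untested among these compounds, so its effect on growth inhibition cannot be told.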